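This account rests on a few compounds, and the source may have more. Where it says the series, first, only, none or still open, it means among the compounds named here.

Measured compounds:
Compound 1, `O=C(/C=C\Nc1ccc(Cl)cc1)c1cn(-c2ccccc2)nc1-c1ccccc1`, 14100 nM.
Compound 2, `O=C(/C=C\Nc1ccc(C(F)(F)F)cc1)c1cn(-c2ccccc2)nc1-c1ccccc1`, giving only a limit, > 50000 nM.
Compound 3, `COc1cc(-c2nn(-c3ccccc3)cc2C(=O)/C=C\Nc2ccc(Cl)cc2)cc(OC)c1OC`, 8670 nM.

The three compounds were tested in a functional assay on A549 cells (Homo sapiens) for antiproliferative activity, read by MTT assay, with a stated time of 48 h; a lower number here means a stronger inhibitor, a higher number a weaker inhibitor. Compound 1 gives a number, while compound 2 reaches only the limit of the measurement, (the limit of > 50000 nM in this assay, at which 1 of the 3 values shown sits), so that the step between them can be given only as a bound. That step, (trifluoromethyl in place of chloro on an aromatic carbon), produced an at least 3.5-fold higher number from compound 1 to compound 2 (0.54 log units; beyond the scatter). Compound 3 carries a different core from compound 1; how the two cores differ is not broken down here. In this assay compound 3 and compound 1 give numbers that lie within the usual scatter of each other, so no order between them can be read.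

Compound 4, `COc1cc(-c2nn(-c3ccccc3)cc2C(=O)/C=C\Nc2ccc(C(F)(F)F)cc2)cc(OC)c1OC`, is not yet measured. It relates to compound 3 by trifluoromethyl in place of chloro on an aromatic carbon, which is the same change that leads from compound 1 to compound 2 and occurs twice among these compounds; the place of the change is described in the same words in both pairs. The account therefore rests on a single measured instance. The step from compound 3 to compound 4 is expected to be a 4.0-fold higher number from compound 3 to compound 4 (0.61 log units; beyond the scatter), because the same change gave an at least 3.5-fold higher number from compound 1 to compound 2 (0.54 log units; beyond the scatter). For compound 4 a value of about 35000 nM is estimated, with a range from 12000 nM to 100000 nM, and it is expected that the assay may report only a limit for compound 4.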

Compound 4, half-maximal inhibitory concentration: > 50000 nM
Compound 4: no number, only a limit; the forecaster's own chance of this, stated with the estimate: 45%; middle value at least 1.4-fold (0.15 log units) from the limit.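

Trifluoromethyl in place of chloro, the change from 4-chlorophenyl to 4-(trifluoromethyl)phenyl, again raises the number in this assay on the second core, with an at least 5.7-fold higher number from compound 3 to compound 4 (0.76 log units; beyond the scatter); this step is a bound, not an exact size, since compound 4 gives only a limit. The change therefore points the same way on both cores shown, and no compound here goes against that direction, although two pairs are a narrow basis and the two bounds do not settle whether the size carries over: the same change on two cores in this assay, an at least 3.5-fold higher number (0.54 log units; beyond the scatter) from compound 1 to compound 2 and an at least 5.7-fold higher number (0.76 log units; beyond the scatter) from compound 3 to compound 4; the limit leaves it open whether they differ The step from compound 2 to compound 4 cannot be read either, so the data do not show whether the 3,4,5-trimethoxyphenyl group alters the outcome once trifluoromethyl is present, and both compounds stop at the same ceiling: the limit of > 50000 nM in this assay, at which 2 of the 4 values shown sit.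

The compounds shown leave open how other groups at this place on the aromatic ring would read, such as a fluoro, a methoxy, a nitrile or a carboxylic acid in place of the chloro. They also leave open whether the same change would keep its direction on a core carrying an amine or a longer chain in place of the 3,4,5-trimethoxyphenyl group.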